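Allenic amines against monoamine oxidase: chloro to methoxy

This account rests on a few compounds, and the source may have more. Where it says the series, first, only, none or still open, it means among the compounds named here.

Measured so far:
Compound 1 `C=C=CCN(C)Cc1ccccc1` gives 8200 nM in an assay on isolated protein for inhibition of Monoamine oxidase (Rattus norvegicus); a lower number here means a stronger inhibitor, a higher number a weaker inhibitor.
Compound 2 `C=C=C(Cc1ccccc1)CN(C)C` gives 25000 nM in this assay.
Compound 3 `C=C=C(CN)Cc1ccc(Cl)cc1` gives 260 nM in this assay.

Compound 3 stands at the lowest number of the three, and its steps to both others lie beyond the usual scatter: compound 1 sits nearest, compound 2 furthest. On these three numbers compound 3 is therefore the strongest inhibitor of the set.

The next compound, compound 4 `C=C=C(CN)Cc1ccc(OC)cc1`, keeps the core of compound 3 and alters only one place: methoxy in place of chloro on an aromatic carbon. Among the measured compounds shown here, no pair of measured compounds differs by this kind of exchange, so nothing shows the size of such a step directly. Compound 4 is expected to give a somewhat higher number than compound 3, a modest weakening that may or may not exceed the scatter, with the step from compound 3 to compound 4 estimated at a 2.7-fold higher number from compound 3 to compound 4 (0.43 log units; beyond the scatter). Compound 4 is thus estimated at 700 nM in this assay, within a range from 200 nM to 2500 nM.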

Compound 4, half-maximal inhibitory concentration: 700 nM
Beside the measured number, compound 4's estimate shows no gap at the digits printed; the measured number falls inside the stated range.
By their numbers in this assay, from the lowest: compound 3; then compound 4; then compound 1; then compound 2.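

In this assay, the exchange of chloro for methoxy on an aromatic carbon gives the series its first step measured at a single place: a 2.7-fold higher number from compound 3 to compound 4 (0.43 log units; beyond the scatter). This position therefore responds to the group it carries, with a modest step that lies beyond the scatter. The exchange adds one heavy atom and one hydrogen-bond acceptor, but no measurement here links the step to either difference or to any other property of the two groups.

Without an unsubstituted ring or a group such as fluoro, methyl or trifluoromethyl at this place on the shared core, the step cannot yet be assigned to chloro or methoxy individually. On these data alone, whether the same exchange gives a step of similar size with a dimethylamino group in place of the amine also remains open.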